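The compounds below may be only part of what the source reports. "The series", "measured", "known", "first", "only" and "open" are said of these compounds alone.

Within the data shown here, in a functional assay on MCF7 cells (Homo sapiens) for antiproliferative activity, read by MTT assay, with a stated time of 48 h (a lower number here means a stronger inhibitor of growth, a higher number a weaker inhibitor of growth), compound 1 (`CCOc1cc(NC(=O)CCCCCCC(=O)Nc2ccccc2N)cc2c1OCC([N+](=O)[O-])=C2`) gives 13500 nM and compound 2 (`CCOc1cc(NC(=O)CCCCCC(=O)Nc2ccccc2N)cc2c1OCC([N+](=O)[O-])=C2`) gives 19500 nM, so compound 2 stands within the scatter of the only other number. Compound 3 (`CCOc1cc(NC(=O)CCCCCNC(=O)CCCc2ccccc2)cc2c1OCC([N+](=O)[O-])=C2`) carries ((3-phenylpropyl)carbonyl)amino in place of (2-aminophenyl)carbamoyl on a saturated chain carbon, five bonds along the chain from a carbonyl carbon. Among the measured compounds shown here, the one measured step, a 1.4-fold higher number from compound 1 to compound 2 (0.16 log units; within the scatter), retains (2-aminophenyl)carbamoyl, and no measured compound lacks it, so support is thin. A modest rise in the number is expected in this assay, with the direction uncertain. The expected step is a 1.3-fold higher number from compound 2 to compound 3 (0.11 log units; within the scatter). Compound 3 is estimated at 25000 nM, within a range of 9000 nM to 70000 nM.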

Compound 3, concentration for 50% growth inhibition: 5960 nM
Beside the measured number, compound 3's estimate is 4.2-fold (0.62 log units) above it; the whole stated range lies above it.
By their numbers in this assay, from the lowest: compound 3; then compounds 1 and 2 (each within the scatter of the next).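

In this assay the (2-aminophenyl)carbamoyl group is not needed for growth inhibition at this saturated chain carbon: ((3-phenylpropyl)carbonyl)amino gives a lower number (a 3.3-fold lower number from compound 2 to compound 3 (0.51 log units; beyond the scatter)). Compared with ((2-aminophenyl)carbamoyl)methyl, it also gives a lower number (a 2.3-fold lower number from compound 1 to compound 3 (0.36 log units; beyond the scatter)), and both steps lie beyond the scatter. Nothing available explains the shift. The compounds shown leave open whether the terminal phenyl or the new amide carries the change. Going by these compounds, a hydroxamic acid, a carboxylic acid or a longer chain at this carbon remains untested here.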